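This account rests on a few compounds, and the source may have more. Where it says the series, first, only, none or still open, it means among the compounds named here.

- Compound 1 `CS(=O)(=O)c1ccc(-c2cnc(N)c(-c3ccc(C(F)(F)F)cc3)c2)cc1`: < 1.6 ug/mL
- Compound 2 `CS(=O)(=O)c1ccc(-c2cnc(N)c(-c3ccc(C#N)cc3)c2)cc1`: 1.6 ug/mL
- Compound 3 `CS(=O)(=O)c1ccc(-c2cnc(N)c(-c3ccc(S(C)(=O)=O)cc3)c2)cc1`: 6.3 ug/mL

These results come from a physicochemical assay for solubility, read by nephelometry, in phosphate buffer, measured as kinetic solubility, with a stated time of 30 min, at pH 6.5; a higher number here means a more soluble compound, a lower number a less soluble compound. The entry for compound 1, < 1.6 ug/mL, is a limit of the assay and not a number. Compound 3, at 6.3 ug/mL, has the highest of the two actual numbers. Compound 4 `CNC(=O)c1ccc(-c2cc(-c3ccc(S(C)(=O)=O)cc3)cnc2N)cc1`, not yet measured, has methylcarbamoyl in place of methylsulfonyl on an aromatic carbon.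

Going by the values given here, no measured step involves methylcarbamoyl, so the guidance is indirect. Methylsulfonyl came in with a modest rise in a 3.9-fold higher number from compound 2 to compound 3 (0.60 log units; beyond the scatter) and again in an at least 3.9-fold higher number from compound 1 to compound 3 (0.59 log units; beyond the scatter), so a fall of similar or smaller size is expected when it is swapped away. The size of a number no lower from compound 1 to compound 2 (the limit leaves the size open) cannot be read. The expected step is a 1.4-fold lower number from compound 3 to compound 4 (0.15 log units; within the scatter). For compound 4 the estimated value is 4.5 ug/mL, with an expected range of 1.6 ug/mL to 13 ug/mL.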

Compound 4, solubility: 25 ug/mL
Beside the measured number, compound 4's estimate is 5.6-fold (0.74 log units) below it; measured number above the stated range.
By their numbers in this assay, from the lowest: compound 2; then compound 3; then compound 4.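

At this position, on an aromatic carbon para to a large group, methylcarbamoyl does better than methylsulfonyl in this assay, so methylsulfonyl is not the best of the groups tried here: a 4.0-fold higher number from compound 3 to compound 4 (0.60 log units; beyond the scatter). The gap to the other two groups is wider still, with a 16-fold higher number from compound 2 to compound 4 (1.19 log units; beyond the scatter) and an at least 15-fold higher number from compound 1 to compound 4 (1.19 log units; beyond the scatter). The last of these steps starts from compound 1, whose entry is a limit and not a number: the limit of < 1.6 ug/mL in this assay, at which 1 of the 4 values shown sits.

On these data alone, whether a carboxylic acid, an amine or a longer chain on the amide nitrogen would give a higher or lower number at this position stays open. So does whether the same swap elsewhere on the shared core would give a step of similar size.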